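The compounds below may be only part of what the source reports. "The series", "measured", "known", "first", "only" and "open" are said of these compounds alone.

Compound 1, with the structure `NC1CCC(Nc2nc(NCc3ccc(Br)cc3)c3ncn(C4CCCC4)c3n2)CC1`, is the starting point of this comparison. Going by the values given here, in a functional assay on G-361 cells (Homo sapiens) for inhibition, with a stated time of 72 h (a lower number here means a stronger inhibitor, a higher number a weaker inhibitor), compound 1 gives 1480 nM, the highest of the three numbers known so far and thus the weakest inhibitor among them. Compound 2 `NC1CCC(Nc2nc(NCc3ccc(-n4cccn4)cc3)c3ncn(C4CCCC4)c3n2)CC1` gives 220 nM, and compound 3 `NC1CCC(Nc2nc(NCc3ccc(-c4ccco4)nc3)c3ncn(C4CCCC4)c3n2)CC1` gives 97 nM. The step of a 6.7-fold lower number from compound 1 to compound 2 (0.83 log units; beyond the scatter) is modest, and the step of a 15-fold lower number from compound 1 to compound 3 (1.18 log units; beyond the scatter) is large; between the two, the step of a 2.3-fold lower number from compound 2 to compound 3 (0.36 log units; beyond the scatter) is again modest.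

The unmeasured compound 4 `NC1CCC(Nc2nc(NCc3ccc(-c4ccsc4)nc3)c3ncn(C4CCCC4)c3n2)CC1` differs from compound 1 in one place: 6-(thiophen-3-yl)pyridin-3-yl in place of 4-bromophenyl on a saturated chain carbon bound to a nitrogen on an aromatic ring. This resembles the change that led to compound 3, where a two-ring group on the same saturated chain carbon replaced the 4-bromophenyl; compound 4 carries a thiophen-3-yl ring on the pyridine where compound 3 carries a furan-2-yl ring. The step from compound 1 to compound 3 is therefore the closest guide, with the step to compound 2 as a second pointer in the same direction. For compound 4 a step of about a 12-fold lower number from compound 1 to compound 4 (1.09 log units; beyond the scatter) is expected, a lower number and so a stronger inhibitor. The estimated value of compound 4 in this assay is 120 nM, with a range from 45 nM to 320 nM.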

Compound 4, half-maximal inhibitory concentration: 272 nM
The estimate for compound 4 lay 2.3-fold (0.36 log units) below the measured number, and the stated range covers the measured number.
By their numbers in this assay, from the lowest: compound 3; then compounds 2 and 4 (each within the scatter of the next); then compound 1.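

In this assay, exchanging only the five-membered ring on the pyridine gives a 2.8-fold higher number from compound 3 to compound 4 (0.45 log units; beyond the scatter) and so shows that the size of the gain over 4-bromophenyl depends on which ring sits there, not just on the presence of a two-ring group. The 6-(thiophen-3-yl)pyridin-3-yl group still gives a stronger inhibitor than 4-bromophenyl, with a 5.4-fold lower number from compound 1 to compound 4 (0.74 log units; beyond the scatter) as the measured step, whereas a 1.2-fold higher number from compound 2 to compound 4 (0.09 log units; within the scatter) is within the scatter, so these two quite different two-ring groups cannot be told apart in this assay. No available measurement explains the difference between the furan-2-yl and thiophen-3-yl rings.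

That exchange alters both the ring's hetero atom, oxygen to sulfur, and the ring carbon through which it is attached, so the compounds shown cannot separate these two changes. A thiophen-2-yl or furan-3-yl ring on the same pyridine would pull them apart, while a small amine on the five-membered ring would test whether this part of the molecule accepts a quite different group.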